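A few compounds are considered here, and "the series" means these few. Any claim that something is new, unique, unknown or untested is made for them only; others in the source may bear on it.

Series notes, measured so far:
- compound 1 `C=C1[C@@H](OC(C)=O)C[C@@H]2[C@](C)(CO[Si](C)(C)C(C)(C)C)[C@H](OC(C)=O)CC[C@@]2(C)[C@@H]1C[C@@H](Nc1ccc(Br)cc1)C1=CCOC1=O`: 3920 nM
- compound 2 `C=C1[C@@H](OC(C)=O)C[C@@H]2[C@](C)(COC=O)[C@H](OC(C)=O)CC[C@@]2(C)[C@@H]1C[C@@H](Nc1ccc(O)cc1)C1=CCOC1=O`: 18100 nM
- compound 3 `C=C1[C@@H](OC(C)=O)C[C@@H]2[C@](C)(CO[Si](C)(C)C(C)(C)C)[C@H](OC(C)=O)CC[C@@]2(C)[C@@H]1C/C=C1/C(=O)OC[C@H]1OC(C)=O`: 4540 nM

In a functional assay on MCF7 cells (Homo sapiens) for cytotoxicity, read by sulforhodamine B assay (on this read-out lower numbers stand for stronger inhibition and higher numbers for weaker inhibition), compound 2 gives 18100 nM, the highest number of the three and beyond the scatter from both of the others. Compound 3 at 4540 nM and compound 1 at 3920 nM lie within the scatter of each other.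

Compound 4 `C=C1[C@@H](OC(C)=O)C[C@@H]2[C@](C)(COC=O)[C@H](OC(C)=O)CC[C@@]2(C)[C@@H]1C[C@@H](Nc1ccc(F)cc1)C1=CCOC1=O` follows from compound 2 through a single change: fluoro in place of hydroxy on an aromatic carbon, para to a large group. Within the data shown here, no two measured compounds differ in one place only, so this assay offers no direct precedent for this step. The closest guide is compound 1, which has a halogen rather than hydroxy on that ring but also differs elsewhere, and it gives 3920 nM. A moderate move to a lower number is therefore expected, though a step within the scatter remains possible. The estimated change is a 2.0-fold lower number from compound 2 to compound 4 (0.30 log units; within the scatter). Compound 4 is expected at 9000 nM, with an estimated range of 3500 nM to 22000 nM.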

Compound 4, half-maximal inhibitory concentration: 12400 nM
Beside the measured number, compound 4's estimate is 1.4-fold (0.14 log units) below it, within the range that was stated.
By their numbers in this assay, from the lowest: compounds 1 and 3 (each within the scatter of the next); then compounds 4 and 2 (each within the scatter of the next).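

In this assay, among these compounds, fluoro in place of hydroxy on an aromatic carbon, para to a large group, gives a 1.5-fold lower number from compound 2 to compound 4 (0.16 log units; within the scatter) and is the only step that differs in one place. At this position, therefore, the hydroxy group, with its hydrogen-bond donor and acceptor, can be exchanged for fluoro, which has neither, without a change beyond the scatter in this single pair. Nothing available bears on the reason for this result.

As far as these compounds go, how an amine, a carboxylic acid or a methoxy group would read at this position remains open. Among the compounds shown here, no single-place step links compound 1 to compound 2 or compound 4, so the separate contributions of its bromo group and silyl ether stay unresolved.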